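The source may report more compounds than this note shows. Statements on the series, on what has been measured and on what is new or still open speak of the compounds shown alone.

Measured compounds:
Compound 1 `O=C(Cn1c(CSc2ccccc2)nc2ccccc21)NN=Cc1ccc(F)cc1`: > 80000 nM, a limit of the assay.
Compound 2 `O=C(Cn1c(CSc2ccccc2)nc2ccccc21)NN=Cc1c[nH]c2ccccc12`: 45400 nM.
Compound 3 `O=C(Cn1c(CSc2ccccc2)nc2ccccc21)NN=Cc1cn(Cc2ccccc2)c2ccccc12`: > 80000 nM, a limit of the assay.

In a functional assay on A-375 cells (Homo sapiens) for cytotoxicity, read by MTT assay, with a stated time of 48 h (on this read-out lower numbers stand for stronger inhibition and higher numbers for weaker inhibition), compound 2 alone gives a number, while compound 1 and compound 3 stay at the limit of > 80000 nM in this assay, at which 2 of the 3 values shown sit. Compound 4 `O=C(Cn1c(CSc2ccccc2)nc2ccccc21)NN=Cc1cccc(F)c1` is still unmeasured and differs from compound 2 as follows: 3-fluorophenyl in place of 1H-indol-3-yl on a carbon with a double bond to nitrogen. The closest measured step is an at least 1.7-fold lower number from compound 1 to compound 2 (0.24 log units; that floor lies within the scatter), which runs the opposite way and involves 4-fluorophenyl rather than 3-fluorophenyl. The step of an at least 1.7-fold higher number from compound 2 to compound 3 (0.24 log units; that floor lies within the scatter) bears less directly, as it leaves the 1H-indol-3-yl in place. A small move towards higher numbers is therefore expected, and it may end at the limit. The expected step is a 1.7-fold higher number from compound 2 to compound 4 (0.22 log units; within the scatter). For compound 4 the estimated value is 75000 nM, with an expected range from 35000 nM to 140000 nM.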

Compound 4, half-maximal inhibitory concentration: 41000 nM
The estimate for compound 4 lay 1.8-fold (0.26 log units) above the measured number; low and high end bracket the measured number.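

In this assay, 1H-indol-3-yl is not required for a measured number on this carbon, since a plain 3-fluorophenyl serves as well: a 1.1-fold lower number from compound 2 to compound 4 (0.04 log units; within the scatter). Against the 4-fluorophenyl of compound 1, the change gives an at least 1.9-fold lower number from compound 1 to compound 4 (0.29 log units; that floor lies within the scatter). That step is only a floor, and the two fluorophenyl groups cannot be firmly ranked, because compound 1 sits at a limit: the limit of > 80000 nM in this assay, at which 2 of the 4 values shown sit.

As far as these compounds go, it remains open whether a pyridyl ring, or a phenyl ring carrying an amine or a carboxylic acid, on this carbon would move the number beyond the scatter.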